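This account rests on a few compounds, and the source may have more. Where it says the series, first, only, none or still open, it means among the compounds named here.

Compound 1 `CC1=C(/C=C/C(=O)/C=C/c2ccccc2F)C(C)(C)CCC1O` gives 2900 nM in a functional assay on LNCaP cells (Homo sapiens) for cytotoxicity, read by MTT assay, with a stated time of 72 h; a lower number here means a stronger inhibitor, a higher number a weaker inhibitor. Compound 2 `CC1=C(/C=C/C(=O)/C=C/c2ccc(F)cc2)C(C)(C)CCC1O` gives 3900 nM in this assay. Compound 3 `CC1=C(/C=C/C(=O)/C=C/c2ccc(F)c(C(F)(F)F)c2)C(C)(C)CCC1O` gives 2200 nM in this assay.

The cores of compound 2 and compound 1 differ by 2-fluorophenyl in place of 4-fluorophenyl on a double-bonded chain carbon bound to a double-bonded chain carbon. From compound 2 to compound 3 the change is trifluoromethyl in place of hydrogen on an aromatic carbon, and this made a 1.8-fold lower number from compound 2 to compound 3 (0.25 log units; within the scatter). Compound 4 `CC1=C(/C=C/C(=O)/C=C/c2cc(C(F)(F)F)ccc2F)C(C)(C)CCC1O` has not yet been measured; it differs from compound 1 by trifluoromethyl in place of hydrogen on an aromatic carbon. Going by the values given here, this is the same kind of change as the one from compound 2 to compound 3, but the surroundings differ: in compound 3 the new group sits ortho to a fluoro group, in compound 4 it sits para to a fluoro group. Resting on the single earlier step, which lay within the scatter, the expected step from compound 1 is a 1.6-fold lower number from compound 1 to compound 4 (0.21 log units; within the scatter). Compound 4 is therefore estimated at 1800 nM, with a range from 800 nM to 4000 nM.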

Compound 4, half-maximal inhibitory concentration: 1700 nM
Compound 4: middle estimate off by 1.1-fold (0.02 log units), on the high side, within the range that was stated.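

Putting trifluoromethyl on the core of compound 1 gave a 1.7-fold lower number from compound 1 to compound 4 (0.23 log units; within the scatter), and in this assay this step matches the one seen on the other core: the same change on two cores in this assay, a 1.8-fold lower number (0.25 log units; within the scatter) from compound 2 to compound 3 and a 1.7-fold lower number (0.23 log units; within the scatter) from compound 1 to compound 4, 1.0-fold (0.02 log units) apart, within the scatter of two such steps

The change therefore carried across these two cores with much the same size. However, each step lies within the scatter, so neither shows that trifluoromethyl truly alters the number, and two cores cannot show how the change would behave across the wider series.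

The compounds shown leave open whether a different group at this place, such as an amine or a carboxylic acid, would give a step beyond the scatter. They also leave open what trifluoromethyl does on a ring with no fluoro group.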